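Propyl in Place of Methoxycarbonyl: What to Expect

This account rests on a few compounds, and the source may have more. Where it says the series, first, only, none or still open, it means among the compounds named here.

In a functional assay on U-87MG ATCC cells (Homo sapiens) for inhibition (on this read-out higher numbers stand for weaker inhibition and lower numbers for stronger inhibition), the measured compounds are:
Compound 1 `COc1cc(/C=C/C(=O)c2cccc(NC(=O)c3ccc(Cl)c(Cl)c3)c2)ccc1O` gives 29.5 ug/mL
Compound 2 `COC(=O)C(=O)Nc1cccc(C(=O)/C=C/c2ccc(O)c(OC)c2)c1` gives 12.2 ug/mL

Compound 2 has the lower number of the two and so is the stronger inhibitor. Compound 3 `CCCC(=O)Nc1cccc(C(=O)/C=C/c2ccc(O)c(OC)c2)c1` changes it at one place (propyl in place of methoxycarbonyl on a carbonyl carbon): propyl in place of methoxycarbonyl on a carbonyl carbon. Going by the values given here, the only measured step at this place is modest (a 2.4-fold lower number from compound 1 to compound 2 (0.38 log units; beyond the scatter)), and no measured compound carries propyl there. A small move toward a higher number, within the scatter, is therefore expected in this assay (a 1.4-fold higher number from compound 2 to compound 3 (0.14 log units; within the scatter)). For compound 3 the estimated value is 17 ug/mL (expected range 8 ug/mL to 36 ug/mL).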

Compound 3, half-maximal inhibitory concentration: 5.56 ug/mL
Estimate against measurement, compound 3: 3.1-fold (0.49 log units) above; measured number below the stated range.
By their numbers in this assay, from the lowest: compound 3; then compound 2; then compound 1.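

In this assay, propyl in place of methoxycarbonyl on this carbonyl carbon gives a 2.2-fold lower number from compound 2 to compound 3 (0.34 log units; beyond the scatter), so the hydrogen-bond acceptors of methoxycarbonyl are not required at this place for stronger inhibition. Propyl in place of 3,4-dichlorophenyl gives a 5.3-fold lower number from compound 1 to compound 3 (0.72 log units; beyond the scatter), which shows that a small open chain without a ring can also serve here, and compound 3 now has the lowest number of the three. Nothing available explains why these numbers move as they do. From the compounds shown here alone, whether a longer chain, or a chain carrying an amine or a carboxylic acid, would lower the number further remains open.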